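A few compounds are considered here, and "the series" means these few. Any claim that something is new, unique, unknown or untested is made for them only; others in the source may bear on it.

Measured in a functional assay with Oryctolagus cuniculus as the target; a lower number here means a stronger inhibitor, a higher number a weaker inhibitor:
- compound 1 `CNC(=N)Nc1nc(-c2ccc(OC)cc2)c(-c2ccc(OC)cc2)s1`: 62 nM
- compound 2 `COc1ccc(-c2nc(/N=C(\N)[N+]3(C)CCCCC3)sc2-c2ccc(OC)cc2)cc1`: > 1000 nM (a limit)
- compound 3 `COc1ccc(-c2nc(/N=C(\N)N3CCOCC3)sc2-c2ccc(OC)cc2)cc1`: < 1000 nM (a limit)

Compound 3 stands only as a limit, < 1000 nM, so there is no number for it. The next structure is compound 4 `COc1ccc(-c2nc(/N=C(\N)n3ccnc3)sc2-c2ccc(OC)cc2)cc1`, and the change is 1H-imidazol-1-yl in place of morpholin-4-yl on a carbon with a double bond to nitrogen.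

For the measured compounds named here, three measured steps bear on this change. The only one with a readable size is the large at least 16-fold higher number from compound 1 to compound 2 (1.20 log units; beyond the scatter), made on an aromatic carbon. The step that the limit leaves unreadable from compound 1 to compound 3 cannot be read. As far as these compounds go, the step of a number no higher from compound 2 to compound 3 (the limit leaves the size open) is the only one on a carbon with a double bond to nitrogen, and its size stays open. Going by the values given here, no measured compound carries 1H-imidazol-1-yl. Since a number no higher from compound 2 to compound 3 (the limit leaves the size open) gives no size for this place, no step beyond the scatter is expected in this assay, and neither direction is favoured. The estimated step is a step that the limit leaves unreadable from compound 3 to compound 4. Compound 4 is estimated at 700 nM, with an expected range from 150 nM to 3000 nM.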

Compound 4, half-maximal inhibitory concentration: > 100 nM
Compound 4 ended at the assay's limit; the forecaster's own chance of this, stated with the estimate: 50%; the middle value lies beyond the limit too.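

In this assay compound 4 gives > 100 nM, and this is a limit, not a number. It extends the place on a carbon with a double bond to nitrogen to a five-membered aromatic ring, 1H-imidazol-1-yl, but it gives no size for that group. For the compounds shown here, the only readable step is an at least 1.6-fold higher number from compound 1 to compound 4 (0.20 log units; that floor lies within the scatter), so the data do not show compound 4 to be weaker than compound 1 beyond the scatter, while the steps that compare 1H-imidazol-1-yl with the two six-membered rings in compound 2 and compound 3 cannot be read.

As far as these compounds go, the order of 1H-imidazol-1-yl and morpholin-4-yl at this place therefore stays open, as does the size of any gap between them. An open-chain amine such as dimethylamino on the same carbon, if it gave a number rather than a limit, would help to place these groups against compound 1.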